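Amide series: pyridin-4-yl in place of 4-methylphenyl

The source may report more compounds than this note shows. Statements on the series, on what has been measured and on what is new or still open speak of the compounds shown alone.

Two amides on a shared core have been measured. Compound 1 `CCCCCCCC(=O)Nc1ccc2[nH]cc(C3CCN(C)CC3)c2n1` carries a heptyl group on the carbonyl carbon; in an assay for binding affinity to 5-hydroxytryptamine receptor 1F (Homo sapiens), read by radioligand binding (on this read-out higher numbers stand for weaker inhibition and lower numbers for stronger inhibition), compound 1 gives 20 nM. Compound 2 `Cc1ccc(C(=O)Nc2ccc3[nH]cc(C4CCN(C)CC4)c3n2)cc1` carries 4-methylphenyl at that carbon, and in this assay compound 2 gives 12 nM. The step of a 1.7-fold lower number from compound 1 to compound 2 (0.22 log units; within the scatter) is within the scatter, so compound 2 holds the lower of the two numbers without being set apart from compound 1.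

Compound 3 `CN1CCC(c2c[nH]c3ccc(NC(=O)c4ccncc4)nc23)CC1` differs from compound 2 by pyridin-4-yl in place of 4-methylphenyl on a carbonyl carbon. Among the measured compounds shown here, no measured step exchanges one aromatic ring for another; the only step available, a 1.7-fold lower number from compound 1 to compound 2 (0.22 log units; within the scatter), replaces a chain with an aromatic ring and lies within the scatter, so it gives no direction for this change. For compound 3 a step of a 2.1-fold higher number from compound 2 to compound 3 (0.32 log units; beyond the scatter) in this assay is expected, with a fair chance that it stays within the scatter. Compound 3 is estimated at 25 nM, range 8 nM to 80 nM.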

Compound 3, inhibition constant: 8.4 nM
Compound 3: the middle estimate sits 3.0-fold (0.47 log units) above what was measured; the range from low to high includes it.
By their numbers in this assay, from the lowest: compounds 3, 2 and 1 (each within the scatter of the next, the first and the last beyond it).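

In this assay, among the compounds shown here, the first exchange of one aromatic ring for another on this carbonyl carbon gives a 1.4-fold lower number from compound 2 to compound 3 (0.15 log units; within the scatter), so replacing 4-methylphenyl with pyridin-4-yl brings no readable change at this position. Pyridin-4-yl in place of heptyl gives a 2.4-fold lower number from compound 1 to compound 3 (0.38 log units; beyond the scatter), a modest step and the first in the series to pass beyond the scatter, which 4-methylphenyl in place of heptyl did not do. No measurement available here bears on the reason for either step.

Still open, as far as these compounds go, is whether pyridin-3-yl, pyridin-2-yl or a five-membered aromatic ring such as thiophen-2-yl on the carbonyl carbon would stay within the scatter of compound 3. A shorter chain such as methyl, or a phenyl ring carrying an amine or a carboxylic acid, also remains to be placed against these three compounds.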